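The source may report more compounds than this note shows. Statements on the series, on what has been measured and on what is new or still open speak of the compounds shown alone.

Within the data shown here, compound 1 `O=S(=O)(c1cc(Cl)cc(Cl)c1)c1cnc2c(F)cccc2c1-c1ccc(F)cc1` is one of two compounds measured so far in an ADME assay on microsomes from liver (Rattus norvegicus) for metabolic stability, tested at 2.5 uM; a lower number here means slower removal, a higher number faster removal of the compound. In this assay compound 1 gives 1.06 mL/min, the higher of the two numbers. Compound 2 `N#Cc1ccc2c(-c3ccc(Cl)cc3)c(S(=O)(=O)c3ccc(F)cc3)cnc2c1` gives 0.01 mL/min in this assay, a gap well beyond the scatter. Compound 3 `O=S(=O)(c1cccc(F)c1)c1cnc2c(F)cccc2c1-c1ccc(F)cc1` is not yet measured; it differs from compound 1 by 3-fluorophenyl in place of 3,5-dichlorophenyl on a sulfonyl sulfur. Among the measured compounds shown here, no measured pair shows this change, so the expected step of a 2.7-fold lower number from compound 1 to compound 3 (0.42 log units; beyond the scatter) is a downward one of modest size, likely just beyond the scatter. The estimate for compound 3 in this assay is 0.4 mL/min, within 0.12 mL/min to 1.3 mL/min.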

Compound 3, intrinsic clearance in a liver preparation (reported as CLH), per the amount of preparation that the assay uses: 0.2 mL/min
Compound 3: the middle estimate sits 2.0-fold (0.30 log units) above what was measured; measured number inside the range.
By their numbers in this assay, from the lowest: compound 2; then compound 3; then compound 1.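

On the sulfonyl sulfur, 3-fluorophenyl in place of 3,5-dichlorophenyl gives a 5.3-fold lower number from compound 1 to compound 3 (0.72 log units; beyond the scatter) in this assay. Among these compounds, this is the first comparison in which only one place differs, and it shows that this group alone can move the number beyond the scatter while the rest of the molecule stays the same. Nothing measured here explains the step. The compounds shown cannot separate losing the chlorines from gaining the fluorine. Plain phenyl or 3-chlorophenyl at this place would address that, and an amine-bearing ring would test a different kind of group.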